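A few compounds are considered here, and "the series" means these few. Any claim that something is new, unique, unknown or untested is made for them only; others in the source may bear on it.

Measured so far:
- compound 1 `N/C(=N\NC(=S)N1CCCCCC1)c1ccccn1`: 3000 nM
- compound 2 `N/C(=N\NC(=S)N1CCCCC1)c1ccccn1`: 6900 nM
- compound 3 `Cc1cccc(/C(N)=N/NC(=S)N2CCCCC2)n1`: 12400 nM

All three were tested in a functional assay on A-431 cells (Homo sapiens) for cytotoxicity, read by MTT assay, with a stated time of 72 h; on this read-out lower numbers stand for stronger inhibition and higher numbers for weaker inhibition. In this assay compound 1 gives 3000 nM, compound 2 gives 6900 nM and compound 3 gives 12400 nM. Compound 1 shows the lowest number of the three; the difference between the core of compound 1 and the core of compound 2 is not broken down here.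

Between compound 2 and compound 3 one change is made: methyl in place of hydrogen on an aromatic carbon. The step of a 1.8-fold higher number from compound 2 to compound 3 (0.25 log units; within the scatter).

Compound 4 `Cc1cccc(/C(N)=N/NC(=S)N2CCCCCC2)n1` is not yet measured. It differs from compound 1 by the same change, at a place described in the same words: methyl in place of hydrogen on an aromatic carbon. Because the step of a 1.8-fold higher number from compound 2 to compound 3 (0.25 log units; within the scatter) was small, a step of similar size is expected here, with compound 4 estimated to sit slightly above compound 1 in this assay.

The expected step is a 1.8-fold higher number from compound 1 to compound 4 (0.26 log units; within the scatter), and compound 4 is estimated at 5500 nM, within a range from 2500 nM to 12000 nM.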

Compound 4, half-maximal inhibitory concentration: 14700 nM
Beside the measured number, compound 4's estimate is 2.7-fold (0.43 log units) below it, and the stated range ends below it.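

In this assay, putting methyl in place of hydrogen on an aromatic carbon gives a 4.9-fold higher number from compound 1 to compound 4 (0.69 log units; beyond the scatter), so on the core of compound 1 this small change costs measurable activity. Among the compounds shown here, the size of the step does not carry over unchanged between the two cores: the same change on two cores in this assay, a 1.8-fold higher number (0.25 log units; within the scatter) from compound 2 to compound 3 and a 4.9-fold higher number (0.69 log units; beyond the scatter) from compound 1 to compound 4, 2.7-fold (0.44 log units) apart, beyond the scatter of two such steps With only one matched pair on each core, this shows that the core can matter for this change, but it does not explain why the two steps differ or predict the step on any further core.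

The compounds shown leave open whether another group at this place, such as an amine, a methoxy group or a chlorine atom, would also give steps that differ between the two cores. They also leave open whether a longer chain, such as ethyl or propyl, in place of methyl would widen or narrow the gap between the steps.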